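Swapping a nitro for an isobutyl on a chalcone amide

A few compounds are considered here, and "the series" means these few. Any claim that something is new, unique, unknown or untested is made for them only; others in the source may bear on it.

Four compounds share one core, an ester-bearing isoxazole joined through a phenyl ring to an amide that carries a chalcone. Compound 3 has the structure `COC(=O)c1cc(-c2cccc(NC(=O)c3ccc(/C=C/C(=O)c4ccc([N+](=O)[O-])cc4)cc3)c2)on1`. In an ADME assay on Vero cells (Chlorocebus sabaeus) for cytotoxicity, read by MTT assay, with a stated time of 72 h (on this read-out higher numbers stand for lower toxicity in this test and lower numbers for higher toxicity in this test), compound 3 gives > 20 ug/mL, which is a limit of the measurement and not a number. Compound 1, the structure `COC(=O)c1cc(-c2cccc(NC(=O)c3ccc(/C=C/C(=O)c4cccc(F)c4)cc3)c2)on1`, was measured as well. In this assay compound 1 gives > 40 ug/mL, again a limit. Compound 2, the structure `COC(=O)c1cc(-c2cccc(NC(=O)c3ccc(/C=C/C(=O)c4cccnc4)cc3)c2)on1`, has "not determined" (no result reported) in this assay. Within the data shown here, the one single-point step among the measured compounds is a step that the two limits leave unreadable from compound 1 to compound 3, and the two limits (the limit of > 20 ug/mL in this assay, at which 1 of the 3 values shown sits, (the limit of > 40 ug/mL in this assay, at which 1 of the 3 values shown sits)) leave its size unreadable.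

Compound 4 is the structure `COC(=O)c1cc(-c2cccc(NC(=O)c3ccc(/C=C/C(=O)c4ccc(CC(C)C)cc4)cc3)c2)on1`. It differs from compound 3 by isobutyl in place of nitro on an aromatic carbon. Among the measured compounds shown here, no measured step tells how such a change moves this assay, and compound 3 itself has only a limit, so the expectation is that compound 4 stays in the same low-toxicity region without a step beyond the scatter, a step that the limit leaves unreadable from compound 3 to compound 4. Compound 4 is therefore estimated at 40 ug/mL, within a range from 15 ug/mL to 100 ug/mL, and a further limit rather than a number is quite possible.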

Compound 4, half-maximal cytotoxic concentration: > 10 ug/mL
Compound 4 ended at the assay's limit; the forecaster's own chance of this, stated with the estimate: 60%; the middle value is on the limit's open side.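

Among these compounds, compound 1, compound 3 and compound 4 all give limits and not numbers in this assay, so neither the change from compound 3 to compound 4 nor the one from compound 1 to compound 4 can be read as a step. The compounds shown leave open how far either change moves toxicity in this test.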